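Moving the Pyridine Nitrogen on the Pyrrole Core

This account rests on a few compounds, and the source may have more. Where it says the series, first, only, none or still open, it means among the compounds named here.

Measured so far:
compound 1 `CC(C)c1cc(-c2ccccc2)c(-c2ccc(F)cc2)n1CC[C@@H]1C[C@@H](O)CC(=O)O1` gives 347 nM
compound 2 `CC(C)c1cc(-c2ccccn2)c(-c2ccc(F)cc2)n1CC[C@@H]1C[C@@H](O)CC(=O)O1` gives 46 nM

In an assay for inhibition of 3-hydroxy-3-methylglutaryl-coenzyme A reductase (Rattus norvegicus) (a lower number here means a stronger inhibitor, a higher number a weaker inhibitor), compound 1 gives 347 nM and compound 2 gives 46 nM. Going by the values given here, compound 2 therefore holds the lowest number of the two measured; its only neighbour is compound 1, and the step of a 7.5-fold lower number from compound 1 to compound 2 (0.88 log units; beyond the scatter) separates them.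

Compound 3 `CC(C)c1cc(-c2cccnc2)c(-c2ccc(F)cc2)n1CC[C@@H]1C[C@@H](O)CC(=O)O1` has not yet been measured. It differs from compound 2 in one spot: pyridin-3-yl in place of pyridin-2-yl on an aromatic carbon. Among the compounds with values here, no measured step compares two pyridines that differ only in where the ring nitrogen sits. Within the data shown here, the single step on record, a 7.5-fold lower number from compound 1 to compound 2 (0.88 log units; beyond the scatter), shows only that exchanging phenyl for pyridin-2-yl on this carbon of the shared core lowered the number; it does not tell whether pyridin-3-yl behaves like pyridin-2-yl or more like phenyl. Without a direct guide, a small step is expected, most likely a somewhat higher number for compound 3 than for compound 2, but staying within the span between compound 1 and compound 2. Compound 3 is expected to give 100 nM in this assay, with a range from 30 nM to 350 nM. That expectation corresponds to a 2.2-fold higher number from compound 2 to compound 3 (0.34 log units; beyond the scatter).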

Compound 3, half-maximal inhibitory concentration: 71 nM
Compound 3: middle estimate off by 1.4-fold (0.15 log units), on the high side, and the stated range covers the measured number.
By their numbers in this assay, from the lowest: compounds 2 and 3 (each within the scatter of the next); then compound 1.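

In this assay, pyridin-3-yl in place of pyridin-2-yl gives a 1.5-fold higher number from compound 2 to compound 3 (0.19 log units; within the scatter), so these two pyridines cannot be told apart at this position, even though their ring nitrogens sit in different places. Pyridin-3-yl in place of phenyl gives a 4.9-fold lower number from compound 1 to compound 3 (0.69 log units; beyond the scatter), a step beyond the scatter and in the same direction as a 7.5-fold lower number from compound 1 to compound 2 (0.88 log units; beyond the scatter). Among these three compounds, then, the clear difference lies between the phenyl ring of compound 1 and either pyridine ring, and the exact placement of the nitrogen does not show up as a separate effect.

No outside measurement is available to explain why either pyridine gives a lower number than phenyl. From the compounds shown here alone, it remains open whether pyridin-4-yl, which puts the ring nitrogen in the one place not yet covered, would fall with compound 2 and compound 3, and whether a pyrimidin-5-yl ring, with a second ring nitrogen, or an aminophenyl ring, with the nitrogen outside the ring, would fall with them or with compound 1.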